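The compounds below may be only part of what the source reports. "The series", "measured", "known", "first", "only" and "open" are said of these compounds alone.

In a functional assay on A549 cells (Homo sapiens) for inhibition, read by MTT assay, with a stated time of 48 h (a lower number here means a stronger inhibitor, a higher number a weaker inhibitor), compound 1 (`Oc1ccc(C(c2c[nH]c3ccc(Br)cc23)c2c[nH]c3ccc(Br)cc23)cc1`) gives 9000 nM and compound 2 (`CN(C)c1ccc(C(c2c[nH]c3ccc(Br)cc23)c2c[nH]c3ccc(Br)cc23)cc1`) gives 25000 nM. Going by the values given here, compound 2 therefore holds the higher of the two numbers so far and is the weaker inhibitor of the pair. Next in the series is compound 3 (`Brc1ccc2[nH]cc(C(c3c[nH]c4ccc(Br)cc34)C3CCCCC3)c2c1`), not yet measured in this assay. It has cyclohexyl in place of 4-(dimethylamino)phenyl on a saturated chain carbon bound to two aromatic carbons. Among the compounds with values here, only one measured step bears on this change, a 2.8-fold higher number from compound 1 to compound 2 (0.44 log units; beyond the scatter), and it is modest. That step swaps dimethylamino and hydroxy on an aromatic carbon, whereas here the whole six-membered aromatic ring leaves, so it is only a loose guide. With compound 2 at the top of the two values at 25000 nM, a small move towards a lower number is expected, no larger than the measured step and possibly within the scatter. The expected step is a 1.7-fold lower number from compound 2 to compound 3 (0.22 log units; within the scatter). For compound 3 the estimated value is 15000 nM, with an expected range of 6000 nM to 40000 nM.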

Compound 3, half-maximal inhibitory concentration: 5500 nM
Estimate against measurement, compound 3: 2.7-fold (0.44 log units) above, and the stated range ends above it.
By their numbers in this assay, from the lowest: compounds 3 and 1 (each within the scatter of the next); then compound 2.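

At the saturated chain carbon bound to two aromatic carbons, the aromatic ring is not required for activity in this assay: cyclohexyl in place of 4-(dimethylamino)phenyl gives a 4.5-fold lower number from compound 2 to compound 3 (0.66 log units; beyond the scatter) and shows that this position tolerates one six-membered non-aromatic ring of carbon only. Set against 4-hydroxyphenyl, the same cyclohexyl gives a 1.6-fold lower number from compound 1 to compound 3 (0.21 log units; within the scatter) and so leaves compound 1 and compound 3 indistinguishable, which makes 4-(dimethylamino)phenyl in compound 2 the only one of the three groups whose number stands apart, beyond the scatter from both others. No supporting measurement accounts for these differences.

Open questions are whether a smaller ring such as cyclopropyl, an open chain such as n-butyl, or a ring carrying an amine such as piperidinyl would keep compound 3's number at this carbon, and whether a carboxylic acid on the cyclohexyl ring would be tolerated. As far as these compounds go, all three compounds also share the same core, so it remains unknown whether the ranking of these groups would hold if the bromine were replaced by chlorine or a methoxy group.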